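The group on sulfur changes again

A few compounds are considered here, and "the series" means these few. Any claim that something is new, unique, unknown or untested is made for them only; others in the source may bear on it.

In a functional assay on A549 cells (Homo sapiens) for inhibition, read by CCK-8 assay, with a stated time of 72 h, tested at 8 uM (on this read-out lower numbers stand for less inhibition of growth and higher numbers for more inhibition of growth at the one concentration tested), compound 1 `COc1ccc(SCc2ccc(/C=C/C(=O)Nc3ccccc3N)cc2)cc1OC` gives 80.6%, compound 2 `Nc1ccccc1NC(=O)/C=C/c1ccc(CSc2ccc(Cl)cc2)cc1` gives 59.6%, and compound 3 `Nc1ccccc1NC(=O)/C=C/c1ccc(CSc2ccc(C(F)(F)F)cn2)cc1` gives 56.5%. Compound 3 thus sits clearly under compound 1, the step being a number 24.1 percentage points lower from compound 1 to compound 3 (beyond the scatter). The 4-chlorophenyl group brought a similar drop, a number 21 percentage points lower from compound 1 to compound 2 (beyond the scatter), and exchanging the two groups changed little: a number 3.1 percentage points lower from compound 2 to compound 3 (within the scatter).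

Compound 4 `Nc1ccccc1NC(=O)/C=C/c1ccc(CSc2ccc(F)cc2)cc1` keeps the shared core and carries 4-fluorophenyl in place of 5-(trifluoromethyl)pyridin-2-yl on a sulfur. Its 4-fluorophenyl group most resembles the 4-chlorophenyl group of compound 2, measured at 59.6%, so the 3,4-dimethoxyphenyl level is not expected. The expected step is a number 3.5 percentage points higher from compound 3 to compound 4 (within the scatter), so none beyond the scatter is anticipated. Compound 4 is estimated at 60%, with an expected range of 45% to 74%.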

Compound 4, percent growth inhibition at one concentration: 59.1%
Estimate against measurement, compound 4: 0.9 percentage points above; the measured number falls inside the stated range.
By their numbers in this assay, from the lowest: compounds 3, 4 and 2 (each within the scatter of the next); then compound 1.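

In this assay, the 4-fluorophenyl group of compound 4 sits level with the 5-(trifluoromethyl)pyridin-2-yl group (a number 2.6 percentage points higher from compound 3 to compound 4 (within the scatter)), and fluoro in place of chloro on an aromatic carbon also makes no difference beyond the scatter (a number 0.5 percentage points lower from compound 2 to compound 4 (within the scatter)). A third group on the sulfur thus joins this level, while the 3,4-dimethoxyphenyl group remains apart (a number 21.5 percentage points lower from compound 1 to compound 4 (beyond the scatter)). Nothing available explains this separation. As far as these compounds go, whether a 4-aminophenyl or 4-hydroxyphenyl group on the sulfur would reach the level of compound 1 remains open.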